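Third Stereoisomer of a Hydroxylated Amide, Stability Expected

A few compounds are considered here, and "the series" means these few. Any claim that something is new, unique, unknown or untested is made for them only; others in the source may bear on it.

Compound 1, `O=C(N[C@H](CO)C(=O)O)[C@@H]1C[C@H](O)CN1`, has been measured in a physicochemical assay for metabolic stability, read by HPLC, with a stated time of 12 h, at pH 4.5; a higher number here means that the compound lasts longer, a lower number that the compound disappears faster. In this assay compound 1 gives > 12 h, which is a limit of the assay rather than a number. Compound 2, `O=C(O)[C@H](CO)NC(=O)[C@@H]1C[C@@H](O)CN1`, has the same atoms and bonds as compound 1 and differs only in configuration as drawn. In this assay compound 2 gives > 12 h, again a limit. The step that the two limits leave unreadable from compound 1 to compound 2 therefore cannot be sized, because the limit of > 12 h in this assay, at which 2 of the 2 values shown sit, caps both values, and the fact that compounds 1 and 2 differ only in the configuration as drawn is all that separates the pair.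

Going by the values given here, compound 3, `O=C(O)[C@@H](CO)NC(=O)[C@H]1C[C@@H](O)CN1`, is the next stereoisomer to be measured. the two compounds have the same atoms and bonds and differ only in configuration as drawn: 2 of 3 stereo elements differ; a stereocentre at a saturated ring carbon is drawn S in compound 1 and R in compound 3; a stereocentre at a saturated ring carbon is drawn S in compound 1 and R in compound 3 The only comparable step, from compound 1 to compound 2, gave no readable change, so no step beyond the scatter is expected here, and the step from compound 1 to compound 3 is estimated as a step that the limit leaves unreadable from compound 1 to compound 3. Compound 3 is expected to give about 24 h, between 12 h and 48 h.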

Compound 3, half-life: > 12 h
Compound 3: a limit, no number; the forecaster's own chance of this, stated with the estimate: 85%; the middle value does not contradict the limit.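

In this assay compound 3 gives > 12 h, which is a limit and not a number. Going by these compounds alone, no step among compound 1, compound 2 and compound 3 can be read, because all three stop at the same limit: the limit of > 12 h in this assay, at which 3 of the 3 values shown sit. The compounds shown leave open how long each one actually lasts, and whether configuration as drawn changes that at all.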